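A few compounds are considered here, and "the series" means these few. Any claim that something is new, unique, unknown or untested is made for them only; others in the source may bear on it.

Working notes on the series.

Of the compounds shown here, three have been measured so far: compound 1 `C#Cc1nc(C(=O)OCC)cs1`, compound 2 `C=Cc1sc(-c2ccc(F)cc2)nc1C(=O)OCC` and compound 3 `Brc1nc2ccccc2o1`. In a functional assay on HCT-116 cells (Homo sapiens) for cytotoxicity, with a stated time of 3 days (on this read-out lower numbers stand for stronger inhibition and higher numbers for weaker inhibition), compound 1 gives > 40000 nM, which is a limit of the assay and not a number. In this assay compound 2 gives > 40000 nM, again a limit. In this assay compound 3 gives > 40000 nM, also a limit. For the measured compounds named here, no step between two measured compounds can be drawn, since every value sits at the limit of > 40000 nM in this assay, at which 3 of the 3 values shown sit. Compound 3 therefore stands nowhere distinct: it is one of three compounds that all reach the same limit.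

The next compound is compound 4 `C#Cc1nc2ccccc2o1`, which differs from compound 3 as ethynyl in place of bromo on an aromatic carbon. Going by the values given here, no measured step gives a guide to the size or direction of this change. Because compound 1 already carries an ethynyl group and gives > 40000 nM, a step that the limit leaves unreadable from compound 3 to compound 4 in this assay is expected, meaning none beyond the scatter. Compound 4 is expected to give about 60000 nM in this assay, within a range of 20000 nM to 200000 nM, most likely reported as a limit.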

Compound 4, half-maximal inhibitory concentration: 11600 nM
Estimate against measurement, compound 4: 5.2-fold (0.71 log units) above, outside the stated range (below it).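

In this assay, ethynyl in place of bromo on an aromatic carbon, next to the ring nitrogen and next to the ring oxygen, gives an at least 3.4-fold lower number from compound 3 to compound 4 (0.53 log units; beyond the scatter). For the compounds shown here, this is the first readable step, and it shows that the number in this assay responds to the group at this position on the shared core. Compound 4 is the only compound shown that gives a number rather than a limit: the limit of > 40000 nM in this assay, at which 3 of the 4 values shown sit.

From the compounds shown here alone, the full size of the step stays open, with compound 3 known only as a limit. Also open, going by these compounds, is whether the triple bond itself matters, and how an amine, a carboxylic acid or a longer chain at this position would read in this assay.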